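The source may hold more compounds than are shown below. What is called first, only, known or untested is meant among the compounds shown, and "the series" means these compounds.

- compound 1 `FC(F)(F)c1ccc(NCc2cn(-c3ccccc3)nc2-c2ccc(Br)cc2)cc1` gives 28000 nM
- compound 2 `FC(F)(F)c1ccc(NCc2cn(-c3ccccc3)nc2-c2ccccc2)cc1` gives 17000 nM

These are the only two results so far in an ADME assay on Vero 76 cells (Chlorocebus sabaeus) for cytotoxicity, read by MTT assay, with a stated time of 96 h; on this read-out higher numbers stand for lower toxicity in this test and lower numbers for higher toxicity in this test. Compound 2 holds the lower number of the pair, but the two values lie within the usual scatter of repeated measurements, so they cannot be told apart.

The next compound, compound 3 `FC(F)(F)c1ccc(NCc2cn(-c3ccccc3)nc2-c2ccc(Cl)cc2)cc1`, has chloro in place of hydrogen on an aromatic carbon, para to a large group (chloro in place of hydrogen on an aromatic carbon). In other words, phenyl becomes 4-chlorophenyl.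

Going by the values given here, only one measured step bears on this change, a swap of bromo for hydrogen on an aromatic carbon. It gave a 1.6-fold lower number from compound 1 to compound 2 (0.22 log units; within the scatter) and stayed inside the scatter, so no step beyond the scatter is expected here. The expected result is a 1.3-fold higher number from compound 2 to compound 3 (0.11 log units; within the scatter) in this assay.

Compound 3 is estimated at 22000 nM with an expected range from 12000 nM to 38000 nM in this assay.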

Compound 3, half-maximal cytotoxic concentration: 18000 nM
Compound 3: middle estimate off by 1.2-fold (0.09 log units), on the high side; the range from low to high includes it.
By their numbers in this assay, from the lowest: compounds 2, 3 and 1 (each within the scatter of the next).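

In this assay, placing chloro para to a large group gives a 1.1-fold higher number from compound 2 to compound 3 (0.02 log units; within the scatter) and swapping bromo for chloro at the same place gives a 1.6-fold lower number from compound 1 to compound 3 (0.19 log units; within the scatter). Until now, this position rested on a single comparison, between bromo and hydrogen; with chloro added, all three pairs among hydrogen, chloro and bromo lie within the scatter, so these three compounds cannot be told apart here. No measurement shown explains why these swaps leave the number within the scatter.

On these data alone, it remains open whether an amine, a carboxylic acid or a methoxy group at this same place would move the number beyond the scatter. Equally open, as far as these compounds go, is how changes elsewhere on the shared core, such as a nitrile in place of trifluoromethyl, would read in this assay in this test.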